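The compounds below may be only part of what the source reports. "The series", "measured", "known", "first", "only" and "open" are said of these compounds alone.

Working notes on the selenium-substituted series.

Compound 2 `CCCCC[Se]c1nc(NCc2ccccc2)c2ccccc2n1` carries a pentyl group on the selenium, and in a functional assay on MCF7 cells (Homo sapiens) for cytotoxicity, read by MTT assay, with a stated time of 72 h (on this read-out lower numbers stand for stronger inhibition of growth and higher numbers for weaker inhibition of growth), compound 2 gives 50 nM. Compound 1 `COc1ccc(CNc2nc([Se]C)nc3ccccc23)cc1`, with a methyl group on the selenium and a methoxy group on the benzyl ring, gives in this assay 42200 nM. Compound 3 `[SeH]c1nc(NCc2ccccc2)c2ccccc2n1` has a bare hydrogen on the selenium. For compound 3 this assay reports only a limit, > 100000 nM, not a number; this is the limit of > 100000 nM in this assay, at which 1 of the 3 values shown sits. Among the compounds with values here, the measured step of an at least 2000-fold higher number from compound 2 to compound 3 (3.30 log units; beyond the scatter) is the only one bearing on a change at the selenium, and it shows that removing the alkyl group leaves compound 3 at the weak end of the values seen.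

Compound 4 `C[Se]c1nc(NCc2ccccc2)c2ccccc2n1` differs from compound 3 by methyl in place of hydrogen on a selenium. Within the data shown here, this is the reverse direction of the one measured step, but with a shorter chain, and compound 1, which also carries a methyl on the selenium, sits far from compound 2. A large decrease in the number from compound 3 to compound 4 is therefore expected, though not down to the level of compound 2 with its 50 nM, an expected step of an at least 3.3-fold lower number from compound 3 to compound 4 (0.52 log units; beyond the scatter). For compound 4 the estimated value in this assay is 30000 nM, with a range from 5000 nM to 100000 nM.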

Compound 4, concentration for 50% growth inhibition: 15800 nM
Compound 4: middle estimate off by 1.9-fold (0.28 log units), on the high side; measured number inside the range.
By their numbers in this assay, from the lowest: compound 2; then compound 4; then compound 1. At a limit, above all of these: compound 3.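

In this assay, methyl in place of hydrogen on a selenium gives an at least 6.3-fold lower number from compound 3 to compound 4 (0.80 log units; beyond the scatter), and that size is only a lower bound, since compound 3 stands at a limit and not at a number: the limit of > 100000 nM in this assay, at which 1 of the 4 values shown sits.

A single methyl on the selenium is therefore enough to bring the series off that limit, but it does not reach the level of the pentyl group, as the change of chain on the selenium gives a 320-fold higher number from compound 2 to compound 4 (2.50 log units; beyond the scatter). The benzyl side also matters in this pair, though less than the chain: hydrogen in place of methoxy on an aromatic carbon gives a 2.7-fold lower number from compound 1 to compound 4 (0.43 log units; beyond the scatter), a modest step but one that lies beyond the scatter.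

The compounds shown hold only methyl and pentyl on the selenium, so it stays open whether the number falls evenly along the chain, and whether a longer chain such as heptyl, or a chain ending in an amine or a carboxylic acid, would go lower still. As far as these compounds go, it is also open whether methoxy on the aromatic carbon would move the number of the pentyl compound by a similar step.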